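Moving the Fluorine: From Compound 1 to Compound 4

This account rests on a few compounds, and the source may have more. Where it says the series, first, only, none or still open, it means among the compounds named here.

Measured so far:
compound 1 `COc1cc(C(=O)N/N=C/c2cccc(F)c2)cc(OC)c1OC`: 13.6%
compound 2 `COc1cc(C(=O)N/N=C/c2cccc(C(F)(F)F)c2)cc(OC)c1OC`: 17.7%
compound 3 `COc1cc(C(=O)N/N=C/c2ccc(C(F)(F)F)cc2)cc(OC)c1OC`: 47.4%

In a functional assay on BGC-823 cells (Homo sapiens) for antiproliferative activity, read by MTT assay, tested at 1 uM (on this read-out lower numbers stand for a weaker effect and higher numbers for a stronger effect at the one concentration tested), compound 1 gives 13.6%, the lowest of the three numbers. Its nearest neighbour is compound 2, and the step of a number 4.1 percentage points higher from compound 1 to compound 2 (within the scatter) stays within the scatter. The furthest is compound 3, which gives 47.4%, a gap well beyond the scatter.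

Compound 4 `COc1cc(C(=O)N/N=C/c2ccccc2F)cc(OC)c1OC` differs from compound 1 in one place: 2-fluorophenyl in place of 3-fluorophenyl on a carbon with a double bond to nitrogen. For the measured compounds named here, the only measured step here, a number 4.1 percentage points higher from compound 1 to compound 2 (within the scatter), swaps one group for another and keeps its place, so it tells little about moving a group. Going by the values given here, compounds 2 and 3 carry the same trifluoromethyl group at different places, and their values lie far apart, which shows that place can matter, but no step of this particular kind has been measured. The expected step of a number 4.4 percentage points higher from compound 1 to compound 4 (within the scatter) is therefore small, with a wide range. Compound 4 is estimated at 18%, between 5% and 40%.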

Compound 4, a percentage reported as inhibition, at one concentration (the size of the read-out at that concentration, not a potency): 51.6%
For compound 4 the middle estimate is 33.6 percentage points below the measured one; measured number above the stated range.
By their numbers in this assay, from the lowest: compounds 1 and 2 (each within the scatter of the next); then compounds 3 and 4 (each within the scatter of the next).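

Replacing 3-fluorophenyl with 2-fluorophenyl, with the same atoms joined differently, gives a number 38 percentage points higher from compound 1 to compound 4 (beyond the scatter) in this assay. On this carbon with a double bond to nitrogen, then, the location of a single fluorine on the phenyl ring can change the read-out strongly, whereas changing the group itself while keeping its location gave only a number 4.1 percentage points higher from compound 1 to compound 2 (within the scatter) and stayed within the usual variation. No accompanying measurement explains why relocating the fluorine has such a large effect.

On these data alone, it remains open whether other groups in the 2-position of the phenyl ring, such as a chlorine atom or an amine, would give a similar read-out to 2-fluorophenyl. As far as these compounds go, it also remains open how the difference between these two fluorophenyl compounds would look as a full potency measurement rather than at one concentration.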